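A Methoxy Group Added to the Amide Phenyl of Compound 1

The source may report more compounds than this note shows. Statements on the series, on what has been measured and on what is new or still open speak of the compounds shown alone.

Measured compounds:
compound 1, `O=C1COc2ccc(-c3cccc(NS(=O)(=O)c4ccc(F)cc4)c3)cc2N1c1ccccc1`: 17700 nM
compound 2, `O=C1COc2ccc(-c3cnc4ccccc4c3)cc2N1c1ccccc1`: > 40000 nM
compound 3, `O=C1COc2ccc(-c3cnc4ccccc4c3)cc2N1`: > 40000 nM

Among the compounds with values here, in a functional assay on HeLa cells (Homo sapiens) for antiproliferative activity, read by MTT assay, with a stated time of 72 h (on this read-out higher numbers stand for weaker inhibition and lower numbers for stronger inhibition), compound 1 gives 17700 nM, the only true number among the three measured compounds. For compound 2 this assay reports only a limit, > 40000 nM. For compound 3 it likewise reports only a limit, > 40000 nM. The step that the two limits leave unreadable from compound 2 to compound 3 is therefore unreadable, both values sitting at the limit of > 40000 nM in this assay, at which 2 of the 3 values shown sit. Compound 4, `COc1ccc(N2C(=O)COc3ccc(-c4cccc(NS(=O)(=O)c5ccc(F)cc5)c4)cc32)cc1`, differs from compound 1 by methoxy in place of hydrogen on an aromatic carbon. No measured step touches this position, so nothing among the shown steps predicts a shift beyond the scatter. The step of no change at the digits printed from compound 1 to compound 4 (within the scatter) is thus expected to stay within the usual scatter. For compound 4 the expected value is 17700 nM, within a range of 7000 nM to 45000 nM.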

Compound 4, half-maximal inhibitory concentration: 13200 nM
Compound 4: the middle estimate sits 1.3-fold (0.13 log units) above what was measured; low and high end bracket the measured number.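

In this assay, within the data shown here, the change from phenyl to 4-methoxyphenyl gives a 1.3-fold lower number from compound 1 to compound 4 (0.13 log units; within the scatter) and is the first readable step at the amide phenyl. This position, on the aromatic carbon para to a large group, therefore takes a methoxy group while the value remains a true number rather than a limit. Nothing measured here bears on a cause for this result. From the compounds shown here alone, whether an amine or a carboxylic acid at this same carbon would shift the value beyond the scatter stays open. So does the effect of a longer chain there, such as ethoxy.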